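Lengthening the Sulfonyl Chain in Urea Inhibitors

The source may report more compounds than this note shows. Statements on the series, on what has been measured and on what is new or still open speak of the compounds shown alone.

Compound 1, `CCCCCCCCC(C)S(=O)(=O)NC(=O)Nc1c(C(C)C)cccc1C(C)C`: 1300 nM
Compound 2, `CCCCCCCCCCS(=O)(=O)NC(=O)Nc1c(C(C)C)cccc1C(C)C`: 13600 nM

Both compounds were tested in an assay on microsomes from liver for inhibition of sterol O-acyltransferase 1 (Rattus norvegicus); a higher number here means a weaker inhibitor, a lower number a stronger inhibitor. Compound 2 gives the highest of the two numbers, and compound 1 gives a lower one; that gap lies beyond the usual scatter. Compound 3, `CCCCCCCCCCCCS(=O)(=O)NC(=O)Nc1c(C(C)C)cccc1C(C)C`, differs from compound 2 by ethyl in place of hydrogen on a saturated chain carbon, ten or more bonds along the chain from a sulfonyl sulfur. Within the data shown here, no measured pair shows this kind of change, so its effect is unknown here; a small step, possibly toward a lower number, or none beyond the scatter, is expected, estimated as a 1.7-fold lower number from compound 2 to compound 3 (0.23 log units; within the scatter). In this assay compound 3 is expected to give 8000 nM, within a range from 2500 nM to 30000 nM.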

Compound 3, half-maximal inhibitory concentration: 3300 nM
Estimate against measurement, compound 3: 2.4-fold (0.38 log units) above; the measured number falls inside the stated range.
By their numbers in this assay, from the lowest: compound 1; then compound 3; then compound 2.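

Ethyl in place of hydrogen on a saturated chain carbon is not a silent change: in this assay the number moves by a 4.1-fold lower number from compound 2 to compound 3 (0.62 log units; beyond the scatter) and the inhibitor becomes stronger. So this far part of the straight chain still matters to the result, even though the change adds only two carbons. Nothing shown here explains this drop.

Going by these compounds, whether a still longer chain would lower the number further remains open, as does the effect of an amine or a carboxylic acid at this position.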